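From cyclobutyl to oxetanyl: what to expect of compound 4

The source may hold more compounds than are shown below. What is called first, only, known or untested is meant among the compounds shown, and "the series" means these compounds.

In an ADME assay on microsomes from liver (Rattus norvegicus), with a stated time of 30 min (a lower number here means that less of the compound is left, a higher number that more of the compound is left), compound 1 `Cc1cc(-c2ccnc3[nH]nc(C(F)(F)F)c23)cc(C2(CN)CCC2)c1` gives 56%. Compound 2 `NCC1(c2cccc(-c3ccnc4[nH]nc(C(F)(F)F)c34)c2)CCC1`, which has hydrogen in place of the methyl group, gives 88%, well clear of compound 1 and beyond the scatter. Compound 3 `NCC1(c2cccc(-c3ccnc4[nH]nc(C(F)(F)F)c34)c2)CCOCC1` gives 65%, which is within the scatter of compound 1.

Compound 4 `Cc1cc(-c2ccnc3[nH]nc(C(F)(F)F)c23)cc(C2(CN)COC2)c1` keeps the core and methyl group of compound 1 and changes one group: 3-(aminomethyl)oxetan-3-yl in place of 1-(aminomethyl)cyclobutyl on an aromatic carbon. The carbon-only four-membered ring thus gives way to one with a hetero atom.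

The closest measured change is a number 23 percentage points lower from compound 2 to compound 3 (beyond the scatter), a modest step in which 4-(aminomethyl)oxan-4-yl takes the place of the same 1-(aminomethyl)cyclobutyl group. For the measured compounds named here, that step points downward, but its entering group differs from the one in compound 4, and its compounds lack the methyl group. The other measured change, a number 32 percentage points higher from compound 1 to compound 2 (beyond the scatter), is large and shows that the methyl group's presence can go with a very different number, so the downward step may not carry over. No step beyond the scatter is therefore expected, only a slight downward lean, and the estimated change is a number 2 percentage points lower from compound 1 to compound 4 (within the scatter). For compound 4 the expected value is 54%, with an estimated range from 30% to 78%.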

Compound 4, percent of the compound remaining: 59%
Estimate against measurement, compound 4: 5 percentage points below; the range from low to high includes it.
By their numbers in this assay, from the lowest: compounds 1, 4 and 3 (each within the scatter of the next); then compound 2.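

In this assay the step from the carbon-only four-membered ring to the oxetane ring is a number 3 percentage points higher from compound 1 to compound 4 (within the scatter), so with the methyl group present, putting an oxygen into this ring at this position leaves no change that the assay can distinguish from scatter. The earlier exchange of the same 1-(aminomethyl)cyclobutyl group, a number 23 percentage points lower from compound 2 to compound 3 (beyond the scatter), brought in a ring of a different size on a core without the methyl group, so a step beyond the scatter does not accompany every such exchange in these compounds. Nothing available here explains why the two exchanges read differently.

Going by these compounds, it remains open what 3-(aminomethyl)oxetan-3-yl would give on the core of compound 2, which has hydrogen in place of the methyl group, and what 4-(aminomethyl)oxan-4-yl would give with the methyl group present. Also open, on these data alone, is how a four-membered ring with nitrogen as its hetero atom, such as an azetidine, or a longer chain such as aminoethyl in place of aminomethyl, would read at this place.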